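A few compounds are considered here, and "the series" means these few. Any claim that something is new, unique, unknown or untested is made for them only; others in the source may bear on it.

Working notes on the series. All members share one core and differ only in the group on the carbonyl carbon of the second amide. Compound 1 `COc1ccccc1C(=O)Nc1cccc(NC(=O)c2cc(Cl)cc(Cl)c2)c1` carries 3,5-dichlorophenyl there, compound 2 `COc1ccccc1C(=O)Nc1cccc(NC(=O)c2ccc(F)cc2)c1` carries 4-fluorophenyl and compound 3 `COc1ccccc1C(=O)Nc1cccc(NC(=O)c2ccco2)c1` carries furan-2-yl. In an in vitro functional assay on HEK293-A cells for antagonist activity at metabotropic glutamate receptor 5 (Rattus norvegicus), read by calcium flux (a lower number here means a stronger inhibitor, a higher number a weaker inhibitor), compound 1 gives only the limit of > 30000 nM and no number. Compound 2 likewise gives only the limit of > 30000 nM in this assay. Compound 3 too gives only the limit of > 30000 nM in this assay. Where compound 3 stands is thus known only as a limit, since every value of the series sits at the limit of > 30000 nM in this assay, at which 3 of the 3 values shown sit. The step that the two limits leave unreadable from compound 1 to compound 2 cannot be sized, nor can the step that the two limits leave unreadable from compound 1 to compound 3 or the step that the two limits leave unreadable from compound 2 to compound 3 be sized.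

Compound 4 `COc1ccccc1C(=O)Nc1cccc(NC(=O)C(C)C)c1` is not yet measured. The change is isopropyl in place of furan-2-yl on a carbonyl carbon. Within the data shown here, no measured step can be read, so no sized step bears on this one; what the three values show is that no member has yet given a number in this assay. The step expected here is a step that the limit leaves unreadable from compound 3 to compound 4 and most likely ends again at the limit. For compound 4 the expected value in this assay is 50000 nM, within a range from 15000 nM to 200000 nM.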

Compound 4, half-maximal inhibitory concentration: > 30000 nM
Compound 4: no number, only a limit; the forecaster's own chance of this, stated with the estimate: 85%; the middle value is on the limit's open side.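

Compound 4 gives only a limit, and no step among compound 1, compound 2, compound 3 and compound 4 can be read in this assay, as all four stand at one limit: the limit of > 30000 nM in this assay, at which 4 of the 4 values shown sit.

The compounds shown leave open whether any group on this carbonyl carbon gives a number in this assay.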